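Aryl substituent swap on the hydrazone terminus

The source may hold more compounds than are shown below. What is called first, only, known or untested is meant among the compounds shown, and "the series" means these compounds.

Measured so far:
- compound 3 `Cc1ccc(/C=N/NC(=O)CSc2nnc(-c3ccncc3)o2)cc1`: 10000 nM
- compound 1 `O=C(CSc1nnc(-c2ccncc2)o1)N/N=C/c1ccc(Cl)cc1`: 15700 nM
- compound 2 `O=C(CSc1nnc(-c2ccncc2)o1)N/N=C/c1ccc(O)cc1`: 5510 nM

In a functional assay on HepG2 cells (Homo sapiens) for cytotoxicity, read by MTT assay, with a stated time of 48 h (a higher number here means a weaker inhibitor, a lower number a stronger inhibitor), compound 3 gives 10000 nM, the second highest of the three numbers. Its nearest neighbour is compound 1 with 15700 nM, and the difference a 1.6-fold lower number from compound 1 to compound 3 (0.20 log units; within the scatter) is within the scatter. Compound 2 gives 5510 nM, and the difference a 1.8-fold higher number from compound 2 to compound 3 (0.26 log units; within the scatter) is likewise within the scatter; only a 2.8-fold lower number from compound 1 to compound 2 (0.45 log units; beyond the scatter) stands beyond it.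

Compound 4 `O=C(CSc1nnc(-c2ccncc2)o1)N/N=C/c1ccccc1[N+](=O)[O-]` differs from compound 3 by 2-nitrophenyl in place of 4-methylphenyl on a carbon with a double bond to nitrogen. The measured steps all exchange one group on the same aromatic ring of the hydrazone terminus and are of modest size at most; none of them introduces a nitro group or alters the ring at the position now concerned. They therefore offer no ground to expect a step beyond the scatter in this assay , in either direction, and the estimate is centred close to compound 3 with a range that reflects the uncertainty of carrying over changes of a different kind.

Compound 4 is expected to give 10000 nM in this assay , within 4000 nM to 30000 nM, the estimated step being no change at the digits printed from compound 3 to compound 4 (within the scatter).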

Compound 4, half-maximal inhibitory concentration: 24700 nM
Beside the measured number, compound 4's estimate is 2.5-fold (0.39 log units) below it; measured number inside the range.
By their numbers in this assay, from the lowest: compounds 2, 3, 1 and 4 (each within the scatter of the next, the first and the last beyond it).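

In this assay, within the data shown here, exchanging the whole aryl group on the carbon with a double bond to nitrogen can move the number beyond the scatter: a 2.5-fold higher number from compound 3 to compound 4 (0.39 log units; beyond the scatter), and a 4.5-fold higher number from compound 2 to compound 4 (0.65 log units; beyond the scatter), the widest step so far, while a 1.6-fold higher number from compound 1 to compound 4 (0.20 log units; within the scatter) stays within it. Compound 4 and compound 1 therefore cannot be told apart, so two different aryl groups now share the top of the range, and the 4-hydroxyphenyl group of compound 2 is the only one separated beyond the scatter from both the 2-nitrophenyl and the 4-chlorophenyl groups. Nothing available explains these steps.

The 2-nitrophenyl group differs from the other aryl groups both in the substituent it carries and in where it carries it, so the compounds shown cannot separate the contribution of the nitro group from that of its location on the ring. From the compounds shown here alone, whether an amino group or a carboxylic acid on this aromatic ring would track with compound 2 or with compound 4 also remains open.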